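A few compounds are considered here, and "the series" means these few. Any claim that something is new, unique, unknown or untested is made for them only; others in the source may bear on it.

Three compounds have been examined in an ADME assay on BV-2 cells (Mus musculus) for cytotoxicity, with a stated time of 24 h, tested at 50 uM; on this read-out lower numbers stand for a stronger effect and higher numbers for a weaker effect at the one concentration tested. Compound 1 `COc1ccccc1S(=O)(=O)/C=C/c1cccnc1` gives 92%. Compound 2 `COc1ccccc1S(=O)(=O)/C=C/c1cccnc1Cl` differs from compound 1 by chloro in place of hydrogen on an aromatic carbon, and in this assay compound 2 gives 87.5%; the step is a number 4.5 percentage points lower from compound 1 to compound 2 (within the scatter). Compound 3 `COc1cccc(S(=O)(=O)/C=C/c2cccnc2)c1` is built from the same atoms as compound 1, joined differently; the difference between the two cores is not broken down here. In this assay compound 3 gives 90.8%, and the numbers of compound 1, compound 2 and compound 3 all lie within the scatter of one another, so no order among them can be read from these data.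

Compound 4 `COc1cccc(S(=O)(=O)/C=C/c2cccnc2Cl)c1` has not yet been measured. It differs from compound 3 by chloro in place of hydrogen on an aromatic carbon, the same change that turns compound 1 into compound 2; among the compounds shown this change occurs twice. Because the measured pair gave a number 4.5 percentage points lower from compound 1 to compound 2 (within the scatter), a step of similar size is expected for compound 4, namely a number 3.8 percentage points lower from compound 3 to compound 4 (within the scatter). This expectation rests on that single measured pair. Compound 4 is therefore estimated at 87%, with a likely range from 80% to 94%.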

Compound 4, a percentage reported as activity, at one concentration (the size of the read-out at that concentration, not a potency): 78.8%
For compound 4 the middle estimate is 8.2 percentage points above the measured one; measured number outside the range, below it.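

In this assay, chloro in place of hydrogen on an aromatic carbon gives a number 12 percentage points lower from compound 3 to compound 4 (beyond the scatter). Set beside the same change on the other core, this step cannot be told apart from the earlier one: the same change on two cores in this assay, a number 4.5 percentage points lower (within the scatter) from compound 1 to compound 2 and a number 12 percentage points lower (beyond the scatter) from compound 3 to compound 4, 7.5 percentage points apart, within the scatter of two such steps. So the results are compatible with the change carrying over between these two cores, but two pairs are too few to show that it has a fixed size on any core, and only the step on the core of compound 3 stands clear of the usual variation between repeats.

The compounds shown leave open whether another group in this same place, next to the ring nitrogen, such as fluoro, methyl or an amine, would lower the number in this assay as chloro does on the core of compound 3. They also leave open whether chloro elsewhere on that ring would give a similar step.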